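The compounds below may be only part of what the source reports. "The series", "measured", "known", "first", "only" and "open" are said of these compounds alone.

Measured in an ADME assay on HEK-293T cells (Homo sapiens) for inhibition, read by CCK-8 assay, with a stated time of 48 h, tested at 20 uM; a higher number here means more inhibition of growth at the concentration tested, a lower number less inhibition of growth:
- Compound 1 `N#C/C(=C\c1ccccc1OS(=O)(=O)c1ccc([N+](=O)[O-])cc1)C(=O)Nc1nnc(Cc2cccc(F)c2)s1`: "not toxic" (no number reported)
- Compound 2 `Cc1ccc(S(=O)(=O)Oc2ccccc2/C=C(\C#N)C(=O)Nc2nnc(Cc3ccc(Cl)cc3)s2)cc1`: 20%

Within the data shown here, compound 2 holds the only number so far, 20%, so there is no numerical series to place it in. Compound 1 has no number and is simply reported as "not toxic" (no number reported).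

Compound 3 `N#C/C(=C\c1ccccc1OS(=O)(=O)c1ccc([N+](=O)[O-])cc1)C(=O)Nc1nnc(Cc2ccc(Cl)cc2)s1` differs from compound 2 in one place: nitro in place of methyl on an aromatic carbon. This is nitro in place of methyl on an aromatic carbon, turning 4-methylphenyl into 4-nitrophenyl. Compound 1 also carries the 4-nitrophenyl and gives "not toxic" (no number reported), so no large increase in this assay is expected from this change. Among the measured compounds shown here, no measured step is available as a guide, and the expectation is for no change beyond the scatter, in either direction. The estimated change is a number 2 percentage points lower from compound 2 to compound 3 (within the scatter). For compound 3 the expected value is 18%, with an estimated range of 3% to 35%.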

Compound 3, percent growth inhibition at one concentration: 19%
Beside the measured number, compound 3's estimate is 1 percentage points below it; low and high end bracket the measured number.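

In this assay, replacing methyl with nitro on the aromatic ring gives a number 1 percentage points lower from compound 2 to compound 3 (within the scatter). This pair is the only one shown that isolates 4-methylphenyl and 4-nitrophenyl with the rest of the molecule unchanged, so it offers a direct test of this position. Here, the larger nitro group, which adds two hydrogen-bond acceptors by the structural count, gives a result that cannot be distinguished from that of methyl, and no measurement shown bears on the reason.

Going by these compounds, it remains open whether an amine or a carboxylic acid in this same place would also stay within the scatter. It is also unknown whether methyl and nitro would remain indistinguishable if another part of the molecule were changed.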